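Phenoxy to phenylsulfanyl on a shared diaminoquinoxaline-type core

This account rests on a few compounds, and the source may have more. Where it says the series, first, only, none or still open, it means among the compounds named here.

Among the compounds with values here, compound 1 `Nc1cc(N)c2nc(-c3ccccc3)c(Oc3ccc(Cl)c(Cl)c3)nc2c1` is the only compound here with a number in a functional assay on A498 cells (Homo sapiens) for inhibition, read by sulforhodamine B assay, with a stated time of 48 h (on this read-out higher numbers stand for weaker inhibition of growth and lower numbers for stronger inhibition of growth), where compound 1 gives 91200 nM. Compound 2 `COc1ccc(CNc2nc3cc(N)cc(N)c3nc2-c2ccccc2)cc1` shares the core, and in this assay compound 2 reaches only a limit of the assay, < 100000 nM; that limit is the one noted as the limit of < 100000 nM in this assay, at which 1 of the 2 values shown sits, and carries no number. Within the data shown here, no step between two measured compounds is available, so nothing measured tells how a change at this position moves the read-out.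

Compound 3 `Nc1cc(N)c2nc(-c3ccccc3)c(Sc3ccc(F)cc3)nc2c1` differs from compound 1 in one place: (4-fluorophenyl)sulfanyl in place of 3,4-dichlorophenoxy on an aromatic carbon of the fused core, next to the ring nitrogen and ortho to a phenyl group. Among the measured compounds shown here, with no measured step to lean on, the change from compound 1 to compound 3 is expected to stay within the usual scatter, a 1.2-fold lower number from compound 1 to compound 3 (0.08 log units; within the scatter). Compound 3 is therefore estimated at 75000 nM in this assay, between 25000 nM and 200000 nM.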

Compound 3, concentration for 50% growth inhibition: < 100000 nM
Compound 3: a limit, no number; the forecaster's own chance of this, stated with the estimate: 35%; the middle value is on the limit's open side.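

In this assay, within the data shown here, compound 3 gives < 100000 nM which is a limit of the assay and not a number, so no new step from compound 1 to compound 3 can be read. The compounds shown leave open how far, and in which direction, (4-fluorophenyl)sulfanyl in place of 3,4-dichlorophenoxy moves growth inhibition.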